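Swapping benzyl for 2-methylphenyl in compound 1

This account rests on a few compounds, and the source may have more. Where it says the series, first, only, none or still open, it means among the compounds named here.

Among the measured compounds shown here, in an ADME assay on microsomes from liver (Rattus norvegicus, strain Sprague-Dawley) for metabolic stability, read by LC-MS, with a stated time of 15 min, tested at 20 uM (on this read-out higher numbers stand for a more stable compound and lower numbers for a less stable compound), compound 1 (`O=C(OCc1ccccc1)c1coc(-c2ccccc2)n1`) gives 2.7%, the lowest of the three numbers measured so far. Compound 3 (`O=C(Oc1cccc2c1CCCC2)c1coc(-c2ccccc2)n1`) stands at 14.5% and compound 2 (`COc1ccccc1CNC(=O)c1c(C)nc2cc(C)ccn12`) at 41.6%, both above compound 1 by more than the scatter.

Compound 4 (`Cc1ccccc1OC(=O)c1coc(-c2ccccc2)n1`) has not yet been measured. It carries 2-methylphenyl in place of benzyl on an oxygen next to a carbonyl group. For the measured compounds named here, no measured pair differs in one place only, so the data give no direct precedent for this change. A small rise in this assay is expected, because compound 1 at 2.7% leaves little room for a fall. The nearest measured number, held by compound 3 at 14.5%, suggests a modest upper reach for that rise. The estimated step is a number 7.3 percentage points higher from compound 1 to compound 4 (within the scatter), upward and not expected to go beyond the scatter. For compound 4 the estimated value is 10%, with an expected range from 2% to 25%.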

Compound 4, percent of the compound remaining: 13.4%
Compound 4: middle estimate off by 3.4 percentage points, on the low side; low and high end bracket the measured number.
By their numbers in this assay, from the lowest: compound 1; then compounds 4 and 3 (each within the scatter of the next); then compound 2.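

Among the compounds shown here, this is the first step between two compounds that differ in one place, and it shows that the read-out at this position responds to the group on the oxygen. In this assay, 2-methylphenyl in place of benzyl on an oxygen next to a carbonyl group gives a number 10.7 percentage points higher from compound 1 to compound 4 (beyond the scatter), a modest step. The two groups match in heavy atoms, aromatic rings, hydrogen-bond donors and acceptors and net charge, so the step arises with those counts unchanged, and nothing among the data explains it.

The compounds shown leave open how a plain phenyl, a cyclohexyl group or a longer chain on the same oxygen would read in this assay. They also leave open whether this step would recur on a core other than that of compound 1.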